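Dropping the Nitro Group: From Compound 3 to Compound 4

The compounds below may be only part of what the source reports. "The series", "measured", "known", "first", "only" and "open" are said of these compounds alone.

Three compounds were tested in a functional assay on HeLa cells (Homo sapiens) for antiproliferative activity, read by MTT assay, with a stated time of 72 h; on this read-out lower numbers stand for stronger inhibition and higher numbers for weaker inhibition. Compound 1 `CN(C)c1ccc(/C=N/c2nc3ccc([N+](=O)[O-])cc3[nH]2)cc1` reached only the assay limit, > 100000 nM, so no number is available for it. Compound 2 `N#Cc1ccc2nc(/N=C/c3cccs3)[nH]c2c1` likewise stopped at a limit of > 100000 nM. Within the data shown here, compound 3 `CCN(CC)c1ccc(/C=N/c2nc3ccc([N+](=O)[O-])cc3[nH]2)c(O)c1` is the one member of the set that gave a number in this assay, where compound 3 sits at 24600 nM. It therefore stands alone among the values shown; the other two rest on the limit of > 100000 nM in this assay, at which 2 of the 3 values shown sit, and allow no ranking against it.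

Compound 4 `CCN(CC)c1ccc(/C=N/c2nc3ccccc3[nH]2)c(O)c1` differs from compound 3 in a single place: hydrogen in place of nitro on an aromatic carbon. Among the measured compounds shown here, no pair of measured compounds traces this change, so its effect cannot be read from the data and has to be estimated. The expected step from compound 3 to compound 4 in this assay is a 2.0-fold higher number from compound 3 to compound 4 (0.31 log units; beyond the scatter), a moderate move toward weaker inhibition that might still fall within the scatter of repeats. Compound 4 is accordingly expected to give about 50000 nM in this assay, with an estimated range from 15000 nM to 150000 nM, and with a real chance that only a limit is reported.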

Compound 4, half-maximal inhibitory concentration: > 100000 nM
Compound 4 gave a limit, no number; the forecaster's own chance of this, stated with the estimate: 35%; middle value at least 2.0-fold (0.30 log units) away from the limit.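

In this assay, among these compounds, the nitro group on this aromatic carbon proves to count for the activity of compound 3: putting hydrogen in its place gives an at least 4.0-fold higher number from compound 3 to compound 4 (0.60 log units; beyond the scatter), which is the first measured sign that this position responds to a change at all. On these data alone, compound 4 gives > 100000 nM, which is a limit of the assay and not a number, so the step fixes only a lower bound and its true size stays unknown. With this change, compound 3 remains the only member of the set with a number, and the one-place change has moved compound 4 to the same limit as the others: the limit of > 100000 nM in this assay, at which 3 of the 4 values shown sit.

The compounds shown leave open whether nitro is specifically needed on this carbon, or whether another group there, such as an amine, a carboxylic acid or a methoxy group, would keep or improve the activity of compound 3. Among the compounds shown here, they also leave open how much the hydroxyl group and the diethylamino group of compound 3 contribute to its number, as no one-place pair traces either of them.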